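A few compounds are considered here, and "the series" means these few. Any claim that something is new, unique, unknown or untested is made for them only; others in the source may bear on it.

Compound 1 `O=C(O[C@H]1C[C@H](n2cc(F)c(=O)[nH]c2=O)O[C@@H]1COP(=O)(O)Oc1ccccc1)c1ccccc1` is the starting point. In a functional assay on U-87MG ATCC cells for cytotoxicity against U-87 MG (Homo sapiens), read by MTT assay, with a stated time of 48 h (a higher number here means a weaker inhibitor, a lower number a stronger inhibitor), compound 1 gives 800 nM, the second highest of the three measured numbers, though all three sit within the scatter of one another: compound 2 `O=C(O[C@H]1C[C@H](n2cc(F)c(=O)[nH]c2=O)O[C@@H]1COP(=O)(O)Oc1ccc2ncccc2c1)c1ccccc1` gives 880 nM in this assay, and compound 3 `C[n+]1cccc(OP(=O)([O-])OC[C@H]2O[C@@H](n3cc(F)c(=O)[nH]c3=O)C[C@@H]2OC(=O)c2ccccc2)c1` gives 590 nM in this assay. The step of a 1.1-fold higher number from compound 1 to compound 2 (0.04 log units; within the scatter) and the step of a 1.4-fold lower number from compound 1 to compound 3 (0.13 log units; within the scatter) each alter a group elsewhere in the molecule, and neither reaches beyond the scatter. Compound 4 `O=c1[nH]c(=O)n([C@H]2C[C@H](O)[C@@H](COP(=O)(O)Oc3ccccc3)O2)cc1F` differs from compound 1 at a different site: hydrogen in place of benzoyl on an oxygen on a saturated carbon. Within the data shown here, no measured step touches this oxygen, so nothing here argues for a shift beyond the scatter. Compound 4 is therefore expected to give about 1000 nM in this assay, within 300 nM to 3500 nM, an estimated step of a 1.3-fold higher number from compound 1 to compound 4 (0.10 log units; within the scatter).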

Compound 4, half-maximal inhibitory concentration: 33700 nM
Estimate against measurement, compound 4: 34-fold (1.53 log units) below, outside the stated range (above it).
By their numbers in this assay, from the lowest: compounds 3, 1 and 2 (each within the scatter of the next); then compound 4.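

Removing the benzoyl from this oxygen on a saturated carbon, leaving hydrogen, gives a 42-fold higher number from compound 1 to compound 4 (1.62 log units; beyond the scatter) in this assay. The two earlier steps, made at a different site, stayed within the scatter, so this is the first single change shown that clearly moves the number. Nothing measured here explains the size of this step.

Only benzoyl and hydrogen are shown on this oxygen, so it stays open whether an acetyl or a methyl group there would keep the number near that of compound 1. On these data alone, it also stays open whether the same change would do the same in compound 2 or compound 3.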